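A Bromo Group Gives Way to Methyl on Compound 3

The compounds below may be only part of what the source reports. "The series", "measured", "known", "first", "only" and "open" are said of these compounds alone.

Three compounds were tested in a functional assay on MCF7 cells (Homo sapiens) for cytotoxicity, read by MTT assay, with a stated time of 48 h; on this read-out lower numbers stand for stronger inhibition and higher numbers for weaker inhibition. Compound 1 `COc1ccc(C(=O)CSC(=S)Nc2cc(OC)c(OC)c(OC)c2)cc1` gave 18.6 ug/mL, and compound 2 `COc1cc(N2C(=S)SCC2(O)c2ccc(Br)cc2)cc(OC)c1OC` gave 16.5 ug/mL; these two numbers sit within the usual scatter of each other, so neither can be set apart from the other. Compound 3 `COc1cc(-n2c(-c3ccc(Br)cc3)csc2=S)cc(OC)c1OC` stands differently: in this assay compound 3 returned only the limit > 100 ug/mL, so no number is known for it, only that it lies at the limit of > 100 ug/mL in this assay, at which 1 of the 3 values shown sits. Among the three, compound 3 is thus the one that does not yield a measured value.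

Compound 4 `COc1cc(-n2c(-c3ccc(C)cc3)csc2=S)cc(OC)c1OC` is the next member and has not yet been measured. The change from compound 3 to compound 4 is methyl in place of bromo on an aromatic carbon, a methyl in place of bromo on an aromatic carbon, para to a large group. Going by the values given here, no step between measured compounds is available, so the size of the effect must be judged from the change alone. Since compound 3 reached only the limit of this assay, the expected step from compound 3 to compound 4 is a number no higher from compound 3 to compound 4 (the limit leaves the size open), with no movement beyond the scatter anticipated in either direction. Compound 4 is therefore estimated to give about 100 ug/mL in this assay, with a likely range from 40 ug/mL to 250 ug/mL, and a fair chance that once again only the limit is reported.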

Compound 4, half-maximal inhibitory concentration: 19.7 ug/mL
The estimate for compound 4 lay 5.1-fold (0.71 log units) above the measured number; measured number below the stated range.
By their numbers in this assay, from the lowest: compounds 2, 1 and 4 (each within the scatter of the next). At a limit, above all of these: compound 3.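

In this assay, going by these compounds alone, this is the first step between compounds that differ in one place, and it shows that this position is not indifferent to what it carries: methyl in place of bromo on an aromatic carbon, para to a large group, gives an at least 5.0-fold lower number from compound 3 to compound 4 (0.70 log units; beyond the scatter). With the 4-methylphenyl group in place of the 4-bromophenyl group, compound 4 returns a measured number, 19.7 ug/mL, while the rest of the structure stays unchanged. Going by these compounds, the true size of the step remains open because compound 3 stands only at a limit of the assay: the limit of > 100 ug/mL in this assay, at which 1 of the 4 values shown sits.

The compounds shown carry only bromo and methyl at this position, and two groups cannot tell whether the step reflects something that methyl brings or something that bromo takes away. On these data alone, how a plain hydrogen, a chlorine, an amine or a carboxylic acid at the same place would read in this assay remains open, as does whether a longer chain such as ethyl would hold the number of compound 4 or lose it.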